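A few compounds are considered here, and "the series" means these few. Any claim that something is new, unique, unknown or untested is made for them only; others in the source may bear on it.

Working notes on the series. Compound 1 `COc1ccc2[nH]cc(C3(c4c[nH]c5ccc(OC)cc45)C(=O)Nc4ccccc43)c2c1` is the reference; in a functional assay on A549 cells (Homo sapiens) for cytotoxicity, read by MTT assay, with a stated time of 48 h (on this read-out higher numbers stand for weaker inhibition and lower numbers for stronger inhibition), compound 1 gives 11200 nM. Compound 3 `COc1ccc2[nH]cc(C3(c4c[nH]c5ccc(OC)cc45)C(=O)Nc4ccc(F)cc43)c2c1` differs from it by fluoro in place of hydrogen on an aromatic carbon, and in this assay compound 3 gives 10600 nM, so that a 1.1-fold lower number from compound 1 to compound 3 (0.02 log units; within the scatter). Compound 2 `O=C1Nc2ccccc2C1(c1c[nH]c2ccc([N+](=O)[O-])cc12)c1c[nH]c2ccc([N+](=O)[O-])cc12` has a different substitution pattern on the shared core; the difference between the two cores is not broken down here. In this assay compound 2 gives 10300 nM, a number within the scatter of both compound 1 and compound 3. Compound 4 `O=C1Nc2ccc(F)cc2C1(c1c[nH]c2ccc([N+](=O)[O-])cc12)c1c[nH]c2ccc([N+](=O)[O-])cc12` is not yet measured; it differs from compound 2 by fluoro in place of hydrogen on an aromatic carbon, the same change, at the same place, as from compound 1 to compound 3. Among the measured compounds shown here, the expected step is a 1.0-fold lower number from compound 2 to compound 4 (0.01 log units; within the scatter), set beside a 1.1-fold lower number from compound 1 to compound 3 (0.02 log units; within the scatter), since only that one pair, compound 1 and compound 3, shows the change. For compound 4 the estimate is 10000 nM, expected to fall between 5000 nM and 20000 nM.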

Compound 4, half-maximal inhibitory concentration: 7700 nM
Estimate against measurement, compound 4: 1.3-fold (0.11 log units) above; low and high end bracket the measured number.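

In this assay, fluoro in place of hydrogen on an aromatic carbon gives a 1.3-fold lower number from compound 2 to compound 4 (0.13 log units; within the scatter) on the second core. The step on this core cannot be told apart from the earlier one on the core of compound 1: the same change on two cores in this assay, a 1.1-fold lower number (0.02 log units; within the scatter) from compound 1 to compound 3 and a 1.3-fold lower number (0.13 log units; within the scatter) from compound 2 to compound 4, 1.3-fold (0.10 log units) apart, within the scatter of two such steps. This agrees with the change carrying across these two cores, but it rests on two pairs with both steps within the scatter, so it shows no real effect of fluoro on either core and says nothing of other cores.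

Going by these compounds, whether chloro, an amine or a carboxylic acid at the same place would move the number remains open. So does whether replacing the amide hydrogen with a longer chain would do so.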